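Replacing an aryl group with an arylamino group on a carbonyl

The compounds below may be only part of what the source reports. "The series", "measured", "known", "first", "only" and "open" are said of these compounds alone.

Measured compounds:
compound 1, `O=C(Nc1cccc(-n2cc(-c3ccncc3)c(-c3ccc(Cl)c(O)c3)n2)c1)Nc1ccc(Cl)c(Cl)c1`, 14300 nM
compound 2, `COc1cc(-c2nn(-c3cccc(NC(=O)c4ccc(Cl)c(C(F)(F)F)c4)c3)cc2-c2ccncc2)ccc1Cl`, > 32500 nM
compound 3, `O=C(Nc1cccc(-n2cc(-c3ccncc3)c(-c3ccc(Cl)c(O)c3)n2)c1)Nc1cc(C(F)(F)F)cc(C(F)(F)F)c1`, 4420 nM

In a functional assay on CAKI-1 cells (Homo sapiens) for inhibition, read by sulforhodamine B assay, with a stated time of 48 h (a higher number here means a weaker inhibitor of growth, a lower number a stronger inhibitor of growth), compound 2 gives only a limit, > 32500 nM, and not a number. Compound 2 therefore sits at the limit of > 32500 nM in this assay, at which 1 of the 3 values shown sits, while compound 1 and compound 3 both give measured numbers within the range of this assay. Compound 1 gives 14300 nM and compound 3 gives 4420 nM in this assay; both of these carry an amino group on the carbonyl carbon, whereas compound 2 carries an aryl group there.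

Compound 4, `COc1cc(-c2nn(-c3cccc(NC(=O)Nc4cccc(C(F)(F)F)c4)c3)cc2-c2ccncc2)ccc1Cl`, keeps the rest of compound 2 and changes only the carbonyl substituent: (3-(trifluoromethyl)phenyl)amino in place of 4-chloro-3-(trifluoromethyl)phenyl on a carbonyl carbon. Compound 4 thus carries an amino group on the carbonyl carbon, as compound 1 and compound 3 do. Going by the values given here, no measured step of exactly this kind exists among the three compounds, so the size of the step is uncertain. Since compound 1 and compound 3 give numbers inside the range, compound 4 is expected to move to a measurable value, a step of an at least 2.9-fold lower number from compound 2 to compound 4 (0.47 log units; beyond the scatter) toward stronger growth inhibition. The estimate for compound 4 in this assay is 11000 nM, with a range from 3500 nM to 32500 nM.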

Compound 4, concentration for total growth inhibition: 3510 nM
Beside the measured number, compound 4's estimate is 3.1-fold (0.50 log units) above it; low and high end bracket the measured number.
By their numbers in this assay, from the lowest: compounds 4 and 3 (each within the scatter of the next); then compound 1. At a limit, above all of these: compound 2.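

In this assay, going by these compounds alone, this is the first comparison of two compounds that differ only in the group on this carbonyl carbon, and the change brings an at least 9.2-fold lower number from compound 2 to compound 4 (0.96 log units; beyond the scatter) toward stronger growth inhibition. Compound 2 gives only a limit, so the step has a known minimum but no known full size: the limit of > 32500 nM in this assay, at which 1 of the 4 values shown sits. The change also alters two things at once, as the entering (3-(trifluoromethyl)phenyl)amino group brings a nitrogen with 1 hydrogen-bond donor, while the chlorine of the leaving 4-chloro-3-(trifluoromethyl)phenyl group is gone.

The compounds shown therefore leave open how much of the step belongs to the added nitrogen and how much to the lost chlorine, a question that (4-chloro-3-(trifluoromethyl)phenyl)amino on the same carbonyl carbon would address. As far as these compounds go, it also remains open whether the nitrogen itself is needed, which an oxygen atom or a methylene group in its place would test.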